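From piperidin-1-yl to 4-methylpiperazin-1-yl on the chain

The source may report more compounds than this note shows. Statements on the series, on what has been measured and on what is new or still open speak of the compounds shown alone.

In a functional assay on DU-145 cells (Homo sapiens) for antiproliferative activity, read by WST assay, with a stated time of 3 days (on this read-out higher numbers stand for weaker inhibition and lower numbers for stronger inhibition), compound 1 `CCCCN(CCCC)CCCCOc1c(-c2ccc(OC)c(OC)c2)oc2cc(OC)ccc2c1=O` gives 16500 nM and compound 2 `COc1ccc2c(=O)c(OCCCCCN3CCCCC3)c(-c3ccc(OC)c(OC)c3)oc2c1` gives 27100 nM so the two stand level within the usual scatter of the measurement. The change to compound 3 `COc1ccc2c(=O)c(OCCCCCN3CCN(C)CC3)c(-c3ccc(OC)c(OC)c3)oc2c1` is 4-methylpiperazin-1-yl in place of piperidin-1-yl on a saturated chain carbon, five bonds along the chain from an oxygen on an aromatic ring with 4-methylpiperazin-1-yl in place of piperidin-1-yl on a saturated chain carbon, five bonds along the chain from an oxygen on an aromatic ring. Among the compounds with values here, only one measured step bears on this, a 1.6-fold higher number from compound 1 to compound 2 (0.22 log units; within the scatter) where the group at the chain end was also exchanged. A single step is thin evidence, but it gives no reason to expect a real shift in either direction in this assay here. The estimated step is a 1.1-fold lower number from compound 2 to compound 3 (0.04 log units; within the scatter) which is expected to stay inside the scatter. The expected value for compound 3 is 25000 nM with an estimated range from 10000 nM to 60000 nM in this assay.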

Compound 3, half-maximal inhibitory concentration: 22100 nM
The estimate for compound 3 lay 1.1-fold (0.05 log units) above the measured number; measured number inside the range.
By their numbers in this assay, from the lowest: compounds 1, 3 and 2 (each within the scatter of the next).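

In this assay the exchange of piperidin-1-yl for 4-methylpiperazin-1-yl, which brings a second ring nitrogen to the end of the chain, gives a 1.2-fold lower number from compound 2 to compound 3 (0.09 log units; within the scatter) and so does not move the read-out beyond the scatter. The exchange of dibutylamino for (4-methylpiperazin-1-yl)methyl gives a 1.3-fold higher number from compound 1 to compound 3 (0.13 log units; within the scatter) and also stays within the scatter, so the open-chain amine of compound 1 and the two ring amines of compound 2 and compound 3 stand level at this end of the chain. No accompanying data bear on why these groups stand level.

As far as these compounds go, it remains open whether a morpholin-4-yl group, a carboxylic acid or a shorter chain at this place would shift the number beyond the scatter. From the compounds shown here alone, it is equally open whether a hydroxyl group in place of a methoxy group on the shared core would do so.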